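A few compounds are considered here, and "the series" means these few. Any claim that something is new, unique, unknown or untested is made for them only; others in the source may bear on it.

Measured so far:
compound 1, `CC(C)c1ccc(N2C(=O)C=CC2OCC(F)(F)F)cc1`, in a functional assay on HeLa cells (Homo sapiens) for inhibition (a higher number here means a weaker inhibitor, a lower number a stronger inhibitor), gives 5800 nM
compound 2, `CCc1ccc(N2C(=O)C=CC2OCC(F)(F)F)cc1`, in this assay gives 6510 nM
compound 3, `O=C1C=CC(OCC(F)(F)F)N1c1ccccc1`, in this assay gives > 100000 nM

Compound 3 stands apart from the other two. Its value in this assay is a limit of the assay and not a number: it sits at the limit of > 100000 nM in this assay, at which 1 of the 3 values shown sits. Both steps that lead to it are large, an at least 17-fold higher number from compound 1 to compound 3 (1.23 log units; beyond the scatter) and an at least 15-fold higher number from compound 2 to compound 3 (1.18 log units; beyond the scatter), so compound 3 is the weakest inhibitor of the three by a clear margin, while compound 1 and compound 2 lie within the scatter of each other, a 1.1-fold higher number from compound 1 to compound 2 (0.05 log units; within the scatter).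

Compound 4, `O=C1C=CC(OCC(F)(F)F)N1c1ccc([N+](=O)[O-])cc1`, differs from compound 3 by nitro in place of hydrogen on an aromatic carbon. For the measured compounds named here, the steps that bear on it are the two that removed an alkyl group from an aromatic carbon of the six-membered aromatic ring of carbon only, an at least 17-fold higher number from compound 1 to compound 3 (1.23 log units; beyond the scatter) and an at least 15-fold higher number from compound 2 to compound 3 (1.18 log units; beyond the scatter), both of them large. Going by the values given here, no measured step covers a nitro group, so the direction is inferred only from the observation that an unsubstituted ring gives the limit in this assay, whereas a substituted ring does not. A step back toward a measurable number is therefore expected, with wide uncertainty. Compound 4 is estimated at 25000 nM, with a range of 5000 nM to 100000 nM, which means an expected step of an at least 4.0-fold lower number from compound 3 to compound 4 (0.60 log units; beyond the scatter).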

Compound 4, half-maximal inhibitory concentration: 2380 nM
Compound 4: the middle estimate sits 11-fold (1.02 log units) above what was measured; measured number below the stated range.
By their numbers in this assay, from the lowest: compound 4; then compounds 1 and 2 (each within the scatter of the next). At a limit, above all of these: compound 3.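

In this assay the value of compound 3 is a limit and not a number, and any step leading from it is a bound only: the limit of > 100000 nM in this assay, at which 1 of the 4 values shown sits.

Nitro in place of hydrogen on an aromatic carbon, para to a large group, gives an at least 42-fold lower number from compound 3 to compound 4 (1.62 log units; beyond the scatter) and so takes the series from that limit to a measured number. The earlier compounds shown here showed this only for ethyl and isopropyl; here a group that is not an alkyl chain does the same, and it goes further, with a 2.7-fold lower number from compound 2 to compound 4 (0.44 log units; beyond the scatter) and a 2.4-fold lower number from compound 1 to compound 4 (0.39 log units; beyond the scatter) making compound 4 the strongest inhibitor of the four, by modest steps.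

With only nitro, ethyl and isopropyl at this position, the compounds shown cannot tell which feature of the entering group sets the number, and an amine, a carboxylic acid, a methoxy group or a halogen there would test how far the trend reaches. Going by these compounds, the rest of the core is the same in all four compounds, so how the number responds to a change elsewhere, for instance a plain ethoxy group in place of the fluorinated chain, stays open.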